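This account rests on a few compounds, and the source may have more. Where it says the series, first, only, none or still open, it means among the compounds named here.

Compound 1 (`CC(=O)c1ccc(NCc2cncn2Cc2ccc(-c3ccccc3)cc2)cc1-c1ccccc1`) is measured in a toxicity assay on NIH3T3 cells (Mus musculus) for cytotoxicity, read by resazurin assay; a higher number here means that more compound is needed for the effect, a lower number that less compound is needed. In this assay compound 1 gives > 10000 nM, which is a limit of the assay and not a number. Its exact position is therefore unknown. A related structure, compound 2 (`N#Cc1ccc(NCc2cncn2Cc2ccc(-c3ccccc3)cc2N)cc1-c1ccccc1`), gives > 1000 nM, and this is a limit as well. For the measured compounds named here, no exact figure is available for either compound, and no pair of measured compounds shows what a single change does in this assay.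

Compound 3 (`c1ccc(-c2ccc(Cn3cncc3CNc3ccc(-c4ccccc4)c(-c4ccccc4)c3)cc2)cc1`) keeps the shared core of compound 1 and changes one group. It has phenyl in place of acetyl on an aromatic carbon, ortho to a phenyl group and para to a large group (phenyl in place of acetyl on an aromatic carbon).

Going by the values given here, with no measured step to go on, the expectation starts from compound 1 and its > 10000 nM. The expected change, a number no higher from compound 1 to compound 3 (the limit leaves the size open), is no larger than the usual scatter. For compound 3 the estimated value is 10000 nM, with an expected range from 3000 nM to 30000 nM.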

Compound 3, half-maximal effective concentration: > 10000 nM
Compound 3 ended at the assay's limit (the forecaster's own chance of this, stated with the estimate: 70%); the middle value sits exactly at the limit.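

In this assay compound 3 gives > 10000 nM and this is a limit of the assay, not a number. For the compounds shown here, compound 1 also stands at a limit, and no step between compound 1 and compound 3 can be read. The compounds shown leave open how much of each is actually needed for the effect, and what phenyl in place of acetyl does to that amount.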